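This account rests on a few compounds, and the source may have more. Where it says the series, first, only, none or still open, it means among the compounds named here.

Measured so far in this series:
compound 1 `CC(C)Oc1cccc(NC(=O)CN2CCC(c3cccc[n+]3[O-])CC2)c1`: 555 nM
compound 2 `O=C(CN1CCC(c2cccc[n+]2[O-])CC1)Nc1cccc(Cl)c1Cl`: 180 nM
compound 3 `Cc1cc(F)ccc1NC(=O)CN1CCC(c2cccc[n+]2[O-])CC1`: 60 nM

In a functional assay on HEK293 cells for agonist activity at D(4) dopamine receptor (Homo sapiens), read by FLIPR (on this read-out lower numbers stand for an effect already at smaller amounts and higher numbers for an effect only at larger amounts of compound), compound 3 gives the lowest number of the three. Within the data shown here, the one step between neighbours that differ in a single place is a 3.0-fold lower number from compound 2 to compound 3 (0.48 log units; beyond the scatter), a modest move; compound 1 gives a higher number still, so the aryl variants measured span from compound 3 up to compound 1.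

Compound 4 `CSc1cccc(NC(=O)CN2CCC(c3cccc[n+]3[O-])CC2)c1` changes the same aryl group: 3-(methylsulfanyl)phenyl in place of 4-fluoro-2-methylphenyl on an amide-type nitrogen. Among the measured compounds shown here, the only measured change at this amide-type nitrogen is a 3.0-fold lower number from compound 2 to compound 3 (0.48 log units; beyond the scatter), so another aryl swap is expected to move this assay by a comparable modest amount, most likely upward, since compound 3 already gives the lowest number. The expected step is a 4.2-fold higher number from compound 3 to compound 4 (0.62 log units; beyond the scatter). Compound 4 is estimated at 250 nM, range 80 nM to 800 nM.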

Compound 4, half-maximal effective concentration: 100 nM
Beside the measured number, compound 4's estimate is 2.5-fold (0.40 log units) above it; measured number inside the range.
By their numbers in this assay, from the lowest: compounds 3, 4 and 2 (each within the scatter of the next, the first and the last beyond it); then compound 1.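

In this assay, 3-(methylsulfanyl)phenyl on the amide-type nitrogen cannot be told apart from the two other aryl groups (a 1.7-fold higher number from compound 3 to compound 4 (0.22 log units; within the scatter) and a 1.8-fold lower number from compound 2 to compound 4 (0.26 log units; within the scatter)). The change on the aromatic carbon, methylsulfanyl in place of isopropoxy, gives the first single-place step involving compound 1 (a 5.6-fold lower number from compound 1 to compound 4 (0.74 log units; beyond the scatter)), so at this carbon the choice of group matters. Nothing at hand explains this step.

As far as these compounds go, it remains open whether a sulfur-free group of similar size, such as ethyl, would match methylsulfanyl here. From the compounds shown here alone, a carboxylic acid or dimethylamino group on this carbon also remains untested in these data.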